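The compounds below may be only part of what the source reports. "The series", "measured", "known", "first", "only" and "open" are said of these compounds alone.

The measured compounds:
Compound 1 `C=CC(=O)Nc1cccc(Nc2ncnc(Nc3ccc(C(=O)Nc4ccccn4)cc3)n2)c1` gave 15600 nM in a functional assay on Raji cells (Homo sapiens) for antiproliferative activity, read by CCK-8 assay, with a stated time of 24 h; a lower number here means a stronger inhibitor, a higher number a weaker inhibitor.
Compound 2 `C=CC(=O)Nc1cccc(Nc2ncnc(Nc3ccc(-c4ccc(OC)nc4)cc3)n2)c1` has as its entry in this assay only "not determined" (no result reported), so no result is reported for it.

Compound 2 therefore has no number to stand on. The only anchor in this small set is compound 1, which in this assay gave 15600 nM, a weak inhibition. Compound 1 and compound 2 share the same core but are not linked by a single measured step, so their structures alone show nothing about how compound 2 would compare. Compound 3 `C=CC(=O)Nc1cccc(Nc2ncnc(Nc3ccc(-c4ccc(F)nc4)cc3)n2)c1` is the next compound, not yet measured. It differs from compound 2 in one place: fluoro in place of methoxy on an aromatic carbon. A methoxy leaves and a fluoro enters on an aromatic carbon of the six-membered aromatic ring with one nitrogen. For the measured compounds named here, no measured step of this kind is on hand, so the size of the step in this assay cannot be read from the data; a shift beyond the scatter in either direction is possible, and so is no shift at all. Compound 3 is expected to land near 8000 nM, within a wide range from 1000 nM to 40000 nM.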

Compound 3, half-maximal inhibitory concentration: 3250 nM
For compound 3 the middle estimate is 2.5-fold (0.39 log units) above the measured one; the measured number falls inside the stated range.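

For the compounds shown here, compound 3 gives the first readable step in this set: in this assay, placing 6-fluoropyridin-3-yl where compound 1 carries (pyridin-2-yl)carbamoyl brings a 4.8-fold lower number from compound 1 to compound 3 (0.68 log units; beyond the scatter), so the group at this place on the shared core does change the read-out, and here towards a stronger inhibitor. The step from compound 2 to compound 3 cannot be read, as compound 2 has no number, so the swap of methoxy for fluoro has no measured size, and the step from compound 1 cannot be credited to the fluoro alone rather than to the whole new group. Nothing on hand explains the shift.

The compounds shown leave open how much the fluoro itself contributes, a question that a plain pyridin-3-yl group, with hydrogen on that carbon next to the ring nitrogen, would help to settle. They also leave open how other small groups on that carbon, such as an amine or a chlorine atom, would compare in this assay.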